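The compounds below may be only part of what the source reports. "The series", "measured", "known", "first", "only" and "open" are said of these compounds alone.

Compound 2, with structure `COc1ccc(N(Cc2ccccc2F)NC(=O)NCCCN2CCN(c3ccccc3OC)CC2)cc1`, is one of two closely related ureas examined in an assay on CHO cells for displacement of a labelled ligand from D(4) dopamine receptor (Homo sapiens), read by radioligand binding; a higher number here means a weaker inhibitor, a lower number a stronger inhibitor. Going by the values given here, compound 2 gives 2.6 nM, and compound 1, `COc1ccccc1N1CCN(CCCNC(=O)NN(Cc2ccccc2F)c2ccc(Cl)cc2)CC1`, gives 2.6 nM; the only measured step, no change at the digits printed from compound 1 to compound 2 (within the scatter), involved a methoxy in place of chloro on an aromatic carbon, and it left the reading within the scatter. Compound 3, `C=CCN(NC(=O)NCCCN1CCN(c2ccccc2OC)CC1)c1ccc(OC)cc1`, carries a different change: vinyl in place of 2-fluorophenyl on a saturated chain carbon bound to a nitrogen on an aromatic ring. Among the compounds with values here, no measured step touches this position, so the step from compound 1 to compound 2 offers no direct guide, only the sign that the periphery of this core has tolerated one substitution without loss. In the change to compound 3 a whole aromatic ring leaves. A moderate weakening is expected for compound 3, as a 5.8-fold higher number from compound 2 to compound 3 (0.76 log units; beyond the scatter). Compound 3 is therefore estimated to show 15 nM, within a range of 3 nM to 80 nM.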

Compound 3, inhibition constant: 61 nM
Compound 3: the middle estimate sits 4.1-fold (0.61 log units) below what was measured; low and high end bracket the measured number.
By their numbers in this assay, from the lowest: compounds 1 and 2 (each within the scatter of the next); then compound 3.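

At this place, on a saturated chain carbon bound to a nitrogen on an aromatic ring, the core does not show the tolerance that the earlier aromatic substitution suggested: in this assay, vinyl in place of 2-fluorophenyl gives a 23-fold higher number from compound 2 to compound 3 (1.37 log units; beyond the scatter) and this large step lies beyond the scatter. Cut one bond further out, the change reads 2-fluorobenzyl to allyl, so the readings tie the stronger value to the group carrying the aromatic ring, for this one pair only. No evidence is available on why the number rises.

From the compounds shown here alone, it remains open whether an unsubstituted benzyl or a cyclohexylmethyl at this place would stay level with compound 2 or move towards compound 3. Going by these compounds, the same change on the chloro compound also remains open.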